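The source may hold more compounds than are shown below. What is called first, only, known or untested is meant among the compounds shown, and "the series" means these compounds.

Compound 1 `CCOC(=O)c1cnn(-c2nc(-c3ccc(N(C)C)cc3)c(C#N)c(=O)n2C)c1N` carries an ethyl ester and an amino group on a pyrazole joined to the shared core. Among the measured compounds shown here, in a functional assay, with a stated time of 10 min (on this read-out higher numbers stand for weaker inhibition and lower numbers for stronger inhibition), compound 1 gives 119 ug/mL, the higher of the two numbers known so far. Compound 2 `COc1cccc(-c2nc(NN)n(C)c(=O)c2C#N)c1OC` has a different substitution on the core, and in this assay compound 2 gives 36 ug/mL. Compound 3 `CCOC(=O)c1cnn(-c2nc(-c3ccc(Cl)cc3)c(C#N)c(=O)n2C)c1N` differs from compound 1 by chloro in place of dimethylamino on an aromatic carbon. For the measured compounds named here, no measured pair shows this change, so the step from compound 1 to compound 3 in this assay is expected to be no larger than a 1.2-fold lower number from compound 1 to compound 3 (0.08 log units; within the scatter), with no direction established. Compound 3 is estimated at 100 ug/mL, between 40 ug/mL and 250 ug/mL.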

Compound 3, half-maximal inhibitory concentration: 94 ug/mL
Compound 3: middle estimate off by 1.1-fold (0.03 log units), on the high side; the range from low to high includes it.
By their numbers in this assay, from the lowest: compound 2; then compounds 3 and 1 (each within the scatter of the next).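

In this assay, among the compounds shown here, chloro in place of dimethylamino on an aromatic carbon, para to a large group, gives a 1.3-fold lower number from compound 1 to compound 3 (0.10 log units; within the scatter) in the first one-place comparison. At this position, 4-(dimethylamino)phenyl and 4-chlorophenyl are therefore not told apart by this read-out. No supporting measurement bears on this result.

Still open, going by these compounds, is whether a carboxylic acid or a longer alkoxy chain on this same aromatic carbon would shift the number beyond the scatter. Also open, on these data alone, is what replacing the ethyl ester would do while the rest of compound 3 stays the same.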